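The source may hold more compounds than are shown below. What is called first, only, known or untested is meant among the compounds shown, and "the series" means these compounds.

Of the compounds shown here, three have so far been measured in a functional assay on CCRF-CEM cells (Homo sapiens) for cytotoxicity, read by cell counting, with a stated time of 3 days; a higher number here means a weaker inhibitor, a lower number a stronger inhibitor. Compound 3 `C=C(Br)C(=O)Nc1ccc(/C=C2\SC(=O)N(CC)C2=O)cc1` gives 870 nM, the lowest of the three numbers and the strongest inhibitor among them. Compound 1 `C=C(Br)C(=O)Nc1ccc(/C=C2\SC(=O)N(Cc3ccccc3)C2=O)cc1` gives 2300 nM. Compound 2 `Nc1ccc(/C=C2\SC(=O)N(Cc3ccc(F)cc3)C2=O)cc1` lacks the amide group that compounds 1 and 3 carry on the shared core; in this assay compound 2 gives 111000 nM. For the measured compounds named here, the only single-point step among the measured compounds is a 2.6-fold lower number from compound 1 to compound 3 (0.42 log units; beyond the scatter), a modest shift beyond the scatter.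

Compound 4 `C=C(Br)C(=O)Nc1ccc(/C=C2\SC(=O)N(Cc3ccc(F)cc3)C2=O)cc1` is the next compound to be examined. It differs from compound 3 by 4-fluorophenyl in place of methyl on a saturated chain carbon bound to an amide-type nitrogen in a ring. Going by the values given here, the step from compound 1 to compound 3 bears directly on this change, since it exchanged phenyl for methyl at the same place; compound 4 reverses that exchange, with fluorine added to the ring, and no measured pair speaks to the fluorine itself. The expected step is therefore a modest rise in the number, a 2.3-fold higher number from compound 3 to compound 4 (0.36 log units; beyond the scatter). Compound 4 is estimated at 2000 nM, within a range from 700 nM to 6000 nM.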

Compound 4, half-maximal inhibitory concentration: 2400 nM
For compound 4 the middle estimate is 1.2-fold (0.08 log units) below the measured one; the measured number falls inside the stated range.
By their numbers in this assay, from the lowest: compound 3; then compounds 1 and 4 (each within the scatter of the next); then compound 2.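

In this assay, 4-fluorophenyl in place of methyl on a saturated chain carbon bound to an amide-type nitrogen in a ring gives a 2.8-fold higher number from compound 3 to compound 4 (0.44 log units; beyond the scatter), the same direction the plain phenyl of compound 1 had shown against methyl. The fluoro group itself leaves no readable mark, with a 1.0-fold higher number from compound 1 to compound 4 (0.02 log units; within the scatter), so that this step stays within the scatter. The (1-bromoethenyl)carbonyl group now has a clean single-place comparison, a 46-fold lower number from compound 2 to compound 4 (1.67 log units; beyond the scatter), a large step that outweighs the modest steps at the chain position.

From the compounds shown here alone, what a propyl chain at this position would give remains open, as does whether chlorine in place of bromine would keep the large step. Nothing available here explains either step.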